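Methyl to methoxy exchange in a two-compound cytotoxicity series

A few compounds are considered here, and "the series" means these few. Any claim that something is new, unique, unknown or untested is made for them only; others in the source may bear on it.

Two compounds carry numbers in a functional assay on L1210 cells (Mus musculus) for cytotoxicity, with a stated time of 48 h; on this read-out lower numbers stand for stronger inhibition and higher numbers for weaker inhibition. Compound 1 `Cc1ccc(/C=C2\CCC/C(=C\c3ccccc3[N+](=O)[O-])C2=O)cc1` gives 7770 nM in this assay. Compound 2 `Cc1ccc(/C=C2\CCC/C(=C\c3cccc([N+](=O)[O-])c3)C2=O)cc1` gives 41800 nM in this assay, the higher of the two numbers; its gap to compound 1 lies beyond the scatter, so compound 2 stands as the weaker of the measured pair. Compound 3 `COc1ccc(/C=C2\CCC/C(=C\c3cccc([N+](=O)[O-])c3)C2=O)cc1` has not been measured in this assay. It differs from compound 2 in one place: methoxy in place of methyl on an aromatic carbon. For the measured compounds named here, no measured pair shows this same exchange, so the data give no step to lean on. The exchange of methyl for methoxy is expected to move the number in this assay little, within the scatter or only just beyond it, with no clear direction. Compound 3 is therefore estimated at 35000 nM, between 12000 nM and 100000 nM, an expected step of a 1.2-fold lower number from compound 2 to compound 3 (0.08 log units; within the scatter).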

Compound 3, half-maximal inhibitory concentration: 29500 nM
Compound 3: the middle estimate sits 1.2-fold (0.07 log units) above what was measured, and the stated range covers the measured number.
By their numbers in this assay, from the lowest: compound 1; then compounds 3 and 2 (each within the scatter of the next).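

In this assay, the change from 4-methylphenyl to 4-methoxyphenyl gives a 1.4-fold lower number from compound 2 to compound 3 (0.15 log units; within the scatter), so the two compounds cannot be told apart on this read-out. For the compounds shown here, compounds 1 and 2 both carry methyl at this place, so this pair is the only view of a change there: on an aromatic carbon para to a large group, one added oxygen and its single hydrogen-bond acceptor leave the number within the scatter. Nothing on hand accounts for this result.

On these data alone, whether the same exchange would leave the number as little moved with the nitro group placed as in compound 1 remains open. Also open, as far as these compounds go, is whether an amine, a carboxylic acid or a longer alkoxy chain at this place would move the number beyond the scatter.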